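Lengthening the acid chain of a flavonol ether

This account rests on a few compounds, and the source may have more. Where it says the series, first, only, none or still open, it means among the compounds named here.

Measured so far:
Compound 1 `CCOC(=O)COc1cc(O)c2c(=O)c(O)c(-c3ccc(OC)cc3)oc2c1CC=C(C)C`, 41600 nM in a functional assay on A549 cells (Homo sapiens) for cytotoxicity, read by MTT assay; a lower number here means a stronger inhibitor, a higher number a weaker inhibitor
Compound 2 `COc1ccc(-c2oc3c(CC=C(C)C)c(OCCCC(=O)O)cc(O)c3c(=O)c2O)cc1`, 19100 nM
Compound 3 `COc1ccc(-c2oc3c(CC=C(C)C)c(OCC(=O)O)cc(O)c3c(=O)c2O)cc1`, 16700 nM

Compound 3 and compound 2 sit within the scatter of each other, as the step of a 1.1-fold lower number from compound 2 to compound 3 (0.06 log units; within the scatter) shows, while both stand beyond the scatter from compound 1, with a 2.5-fold lower number from compound 1 to compound 3 (0.40 log units; beyond the scatter) and a 2.2-fold lower number from compound 1 to compound 2 (0.34 log units; beyond the scatter). Compound 4 `COc1ccc(-c2oc3c(CC=C(C)C)c(OC/C=C/C(=O)O)cc(O)c3c(=O)c2O)cc1` differs from compound 3 only in 2-carboxyethenyl in place of carboxy on a saturated chain carbon bound to an oxygen on an aromatic ring. The step that bears on this is a 1.1-fold lower number from compound 2 to compound 3 (0.06 log units; within the scatter), since it too swaps carboxy against a longer acid chain on the same carbon, and it stayed within the scatter. A step from compound 3 to compound 4 of about a 1.0-fold higher number from compound 3 to compound 4 (0.01 log units; within the scatter) is therefore expected, none beyond the scatter. Compound 4 is estimated at 17000 nM, within 8000 nM to 36000 nM.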

Compound 4, half-maximal inhibitory concentration: 22900 nM
Compound 4: the middle estimate sits 1.3-fold (0.13 log units) below what was measured; the range from low to high includes it.
By their numbers in this assay, from the lowest: compounds 3, 2, 4 and 1 (each within the scatter of the next, the first and the last beyond it).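

The 2-carboxyethenyl chain stays within the scatter of both other acid chains at this position, with a 1.4-fold higher number from compound 3 to compound 4 (0.14 log units; within the scatter) and a 1.2-fold higher number from compound 2 to compound 4 (0.08 log units; within the scatter) in this assay. Unlike those two acids, it also stays within the scatter of the ethoxycarbonyl chain, with a 1.8-fold lower number from compound 1 to compound 4 (0.26 log units; within the scatter), which blurs the earlier split between acids and ester. Nothing available explains these small steps.

All the chains shown end in a carboxylic acid or its ethyl ester. As far as these compounds go, whether an amide or an amine at the chain end would give a step beyond the scatter stays open.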